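The compounds below may be only part of what the source reports. "The series", "measured", "known", "first", "only" and "open" are said of these compounds alone.

Measured compounds:
- compound 1 `Cn1c(-c2ccc(F)cc2)nc2c(NC3CCCC3)ncnc21`, in an assay on CHO cells for displacement of a labelled ligand from adenosine receptor A1 (Homo sapiens), read by scintillation counting, with a stated time of 3 h (on this read-out lower numbers stand for stronger inhibition and higher numbers for weaker inhibition), compound 1 gives 6.2 nM
- compound 2 `Cn1c(-c2cccnc2)nc2c(NC3CCCC3)ncnc21`, in this assay compound 2 gives 242 nM

For the measured compounds named here, compound 2 stands at the higher of the two numbers measured so far; its nearest neighbour is compound 1, and the only step recorded, a 39-fold higher number from compound 1 to compound 2 (1.59 log units; beyond the scatter), separates them. That single step is the one that bears on the next change.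

Compound 3 `Cn1c(-c2ccc(Cl)cc2)nc2c(NC3CCCC3)ncnc21` is not yet measured. It differs from compound 2 by 4-chlorophenyl in place of pyridin-3-yl on an aromatic carbon. This change puts a ring of carbon only back in the place where compound 1 already carries a 4-fluorophenyl. Going by the values given here, the one measured step, a 39-fold higher number from compound 1 to compound 2 (1.59 log units; beyond the scatter), is thus largely retraced in the opposite direction by the change from compound 2 to compound 3, with chlorine in place of fluorine as the residual difference. Among the compounds with values here, no measured pair reports the fluorine-to-chlorine exchange itself, so that part of the change is left open.

Compound 3 is therefore expected to land close to compound 1, with a step of a 30-fold lower number from compound 2 to compound 3 (1.48 log units; beyond the scatter) toward lower numbers. The estimate for compound 3 in this assay is 8 nM, within the range 2.5 nM to 25 nM.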

Compound 3, inhibition constant: 18 nM
Compound 3: middle estimate off by 2.3-fold (0.35 log units), on the low side; the range from low to high includes it.
By their numbers in this assay, from the lowest: compound 1; then compound 3; then compound 2.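

In this assay, 4-chlorophenyl in place of pyridin-3-yl gives a 13-fold lower number from compound 2 to compound 3 (1.13 log units; beyond the scatter), so at this aromatic carbon two different halogen-bearing rings of carbon only, not just the 4-fluorophenyl, now sit on the low-number side of pyridin-3-yl. The halogen itself also counts: chloro in place of fluoro gives a 2.9-fold higher number from compound 1 to compound 3 (0.46 log units; beyond the scatter), a modest step but one beyond the scatter, so the 4-chlorophenyl ring does not fully return to the number of the 4-fluorophenyl ring, and the large gain over pyridin-3-yl comes with a smaller, separate effect of the exchange between the two halogens. No measurement at hand says why either step has its size.

Open, on these data alone, is where an unsubstituted phenyl would fall relative to these three compounds, and with it how much of the gap belongs to the ring nitrogen of pyridin-3-yl and how much to the halogen. Also open, as far as these compounds go, is whether a 4-methoxyphenyl, or an amine or carboxylic acid on the same ring, would keep the number low, and whether the same order holds with a longer chain in place of the methyl group.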